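Swapping fluoro for bromo on a shared urea core

This account rests on a few compounds, and the source may have more. Where it says the series, first, only, none or still open, it means among the compounds named here.

Of the compounds shown here, three have been measured so far in an ADME assay on the whole organism with Oryza sativa as the target, tested at 1 uM; on this read-out higher numbers stand for a weaker effect at the one concentration tested and lower numbers for a stronger effect. Compound 1, `C[C@@H](NC(=O)Nc1cccc(F)c1)c1ccccc1`, gives 95%. Compound 2, `C[C@@H](NC(=O)Nc1ccc(F)cc1)c1ccccc1`, gives 96%. Compound 3, `C[C@@H](NC(=O)Nc1cccc(Br)c1)c1ccccc1`, gives 100%. Compounds 1 and 2 are built from the same atoms joined differently, and the difference between the two cores is not broken down here; their values lie within the usual scatter of each other, so no order between them can be claimed.

One change has been made once among the measured compounds: bromo in place of fluoro on an aromatic carbon. This carried a number 5 percentage points higher from compound 1 to compound 3 (within the scatter), a step that stays within the scatter, so the read-out is essentially unchanged by it.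

Compound 4, `C[C@@H](NC(=O)Nc1ccc(Br)cc1)c1ccccc1`, has not yet been measured. It arises from compound 2 by bromo in place of fluoro on an aromatic carbon. The halogen now sits para to a large group rather than meta to it. This is the same kind of change as that from compound 1 to compound 3, not the same one.

Among the measured compounds shown here, the expectation for compound 4 in this assay rests on the single measured step, from compound 1 to compound 3, of a number 5 percentage points higher from compound 1 to compound 3 (within the scatter); a similar small step, a number 4 percentage points higher from compound 2 to compound 4 (within the scatter), is expected here. Compound 4 is therefore estimated at 100%, most likely between 88% and 108%.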

Compound 4, a percentage reported as activity, at one concentration (the size of the read-out at that concentration, not a potency): 95%
For compound 4 the middle estimate is 5 percentage points above the measured one; measured number inside the range.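

In this assay, the swap of bromo for fluoro on the second core gives a number 1 percentage points lower from compound 2 to compound 4 (within the scatter), so here too the read-out is essentially unchanged. Set beside the earlier case, the same change on the two cores gives steps that cannot be told apart, which means that in this small series the swap can be carried from one core to the other without a visible difference in the read-out: the same change on two cores in this assay, a number 5 percentage points higher (within the scatter) from compound 1 to compound 3 and a number 1 percentage points lower (within the scatter) from compound 2 to compound 4, 6 percentage points apart, within the scatter of two such steps. Among the compounds shown here, this shows only that the swap had no detectable effect on these two closely related cores, at one concentration and in this one assay, and with only two cases it does not establish a rule for other cores or say how the two halogens would compare in any other test.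

On these data alone, all four compounds carry a single halogen on the aromatic ring, and their values stay close together, so it remains open what would happen with a group of a different kind in that place, such as an amine or a carboxylic acid. As far as these compounds go, it is equally open whether a longer chain in place of the methyl group would move the read-out beyond the usual scatter.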